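A few compounds are considered here, and "the series" means these few. Any claim that something is new, unique, unknown or untested is made for them only; others in the source may bear on it.

Measured compounds and their maximal responses:
compound 1, `CCCn1ncnc1-c1ccccc1NCC1=NCCN1`, 96%;
compound 2, `CCn1ncnc1-c1ccccc1NCC1=NCCN1`, 107%;
compound 3, `c1ccc(-c2cn[nH]c2)c(NCC2=NCCN2)c1`, 112%.

All three were tested in a functional assay with Alpha-1A adrenergic receptor (Homo sapiens) as the target, read by calcium flux; on this read-out lower numbers stand for smaller maximal responses and higher numbers for larger maximal responses. Compound 3 shows the largest number of the three, but the gap to compound 2 lies within the scatter, so the two cannot be ranked; only the gap to compound 1 is beyond it. Compound 4, `Cn1ncnc1-c1ccccc1NCC1=NCCN1`, has not yet been measured. It differs from compound 3 in one place: 1-methyl-1H-1,2,4-triazol-5-yl in place of 1H-pyrazol-4-yl on an aromatic carbon. The new group sits on an aromatic carbon of a six-membered aromatic ring of carbon only.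

For the measured compounds named here, no measured pair shows this exact exchange. The closest guide is the step from compound 1 to compound 2, a number 11 percentage points higher from compound 1 to compound 2 (beyond the scatter), where a shorter chain on the aromatic nitrogen went with a modestly higher number. Compound 4 carries the shortest such chain, and compounds 2 and 3 already sit close together, so no change beyond the scatter is expected for this assay. The estimate for compound 4 is therefore 108%, within 90% to 125%, which means an expected step of a number 4 percentage points lower from compound 3 to compound 4 (within the scatter).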

Compound 4, largest response reached (reported as maximal response), in percent of the reference or control that the assay uses: 91%
Estimate against measurement, compound 4: 17 percentage points above, and the stated range covers the measured number.
By their numbers in this assay, from the lowest: compounds 4 and 1 (each within the scatter of the next); then compounds 2 and 3 (each within the scatter of the next).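

In this assay, the exchange on this aromatic carbon, ortho to a group of 7 heavy atoms, gives a number 21 percentage points lower from compound 3 to compound 4 (beyond the scatter), so this position does respond to the change from 1H-pyrazol-4-yl to 1-methyl-1H-1,2,4-triazol-5-yl. Chain length on the triazole nitrogen also proves not to act in one direction: shortening propyl to ethyl gave a number 11 percentage points higher from compound 1 to compound 2 (beyond the scatter), whereas shortening ethyl to methyl gives a number 16 percentage points lower from compound 2 to compound 4 (beyond the scatter). The two ends of this short series cannot be told apart, with a number 5 percentage points lower from compound 1 to compound 4 (within the scatter), so among these three chains only the ethyl of compound 2 stands out, and nothing available here explains these differences.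

The exchange from compound 3 to compound 4 alters several things at once: the ring gains a nitrogen, a methyl is added and the hydrogen-bond donor is lost, so a 1-methyl-1H-pyrazol-4-yl group at the same position would be needed to begin separating these changes. From the compounds shown here alone, it also remains open whether a butyl chain or a cyclopropyl group on the triazole nitrogen would follow the ethyl compound or the methyl compound.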